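The source may report more compounds than this note shows. Statements on the series, on what has been measured and on what is new or still open speak of the compounds shown alone.

Measured so far:
- compound 1 `Nc1ccccc1/N=C\c1cc(=O)oc2cc(OCc3ccccc3)ccc12`: 217000 nM
- compound 2 `Nc1ccccc1/N=C\c1cc(=O)oc2cc(OCc3ccccc3)cc(OCc3ccccc3)c12`: 258000 nM
- compound 3 `O=c1cc(/C=N\Nc2ccccc2)c2c(OCc3ccccc3)cc(OCc3ccccc3)cc2o1`: 303000 nM

In a functional assay, read by spectrophotometry, with a stated time of 5 min (a lower number here means a stronger inhibitor, a higher number a weaker inhibitor), compound 1 gives 217000 nM; compound 2, which adds a benzyloxy, sits at a 1.2-fold higher number from compound 1 to compound 2 (0.08 log units; within the scatter), and compound 3 is separated from compound 1 by a gap that is also within the scatter. All three therefore read as essentially alike. Compound 4 `O=c1cc(/C=N\Nc2ccc([N+](=O)[O-])cc2)c2ccc(OCc3ccccc3)cc2o1` is related to compound 1 by the change ((4-nitrophenyl)amino in place of 2-aminophenyl on a double-bonded nitrogen). Going by the values given here, the one measured step that resembles this change is a 1.2-fold higher number from compound 2 to compound 3 (0.07 log units; within the scatter), which also swapped the 2-aminophenyl for an aryl-amino group and moved the number hardly at all. On that basis the estimated step is a 1.2-fold higher number from compound 1 to compound 4 (0.06 log units; within the scatter), no larger than the scatter, and compound 4 is expected to give about 250000 nM, within 100000 nM to 600000 nM.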

Compound 4, half-maximal inhibitory concentration: > 2000000 nM
Compound 4: only a limit was reported; the forecaster's own chance of this, stated with the estimate: 15%; middle value at least 8.0-fold (0.90 log units) away from the limit.
By their numbers in this assay, from the lowest: compounds 1, 2 and 3 (each within the scatter of the next). At a limit, above all of these: compound 4.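

The group on the double-bonded nitrogen does not always leave the number unchanged: (4-nitrophenyl)amino in place of 2-aminophenyl gives an at least 9.2-fold higher number from compound 1 to compound 4 (0.96 log units; beyond the scatter), whereas anilino in the same place gave a 1.2-fold higher number from compound 2 to compound 3 (0.07 log units; within the scatter). The full size of this step cannot be stated because compound 4 reached a limit, not a number: the limit of > 2000000 nM in this assay, at which 1 of the 4 values shown sits.

Whether the nitro group itself accounts for the step remains open. So does how an amine or a methoxy group in its place would read, and whether the step would hold on the core of compound 2.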